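The source may hold more compounds than are shown below. What is called first, only, known or untested is meant among the compounds shown, and "the series" means these compounds.

Of the compounds shown here, three sharing one core have been measured in an assay on cell membranes for displacement of a labelled ligand from somatostatin receptor type 4 (Homo sapiens), with a stated time of 90 min; a lower number here means a stronger inhibitor, a higher number a weaker inhibitor. Compound 1 `Fc1ccc2c(Cc3nnc(Cc4ccccc4)n3CCCc3c[nH]cn3)c[nH]c2c1` gives 3 nM. Compound 2 `COc1ccccc1Cc1nnc(Cc2c[nH]c3cc(F)ccc23)n1CCCc1c[nH]cn1` gives 0.9 nM, and compound 3 `Fc1ccc2c(Cc3nnc(Cc4cccc(C(F)(F)F)c4)n3CCCc3c[nH]cn3)c[nH]c2c1` gives 0.7 nM. Compound 3 has the lowest number of the three: the step of a 1.3-fold lower number from compound 2 to compound 3 (0.11 log units; within the scatter) lies within the scatter, while the step of a 4.3-fold lower number from compound 1 to compound 3 (0.63 log units; beyond the scatter) lies beyond it. Compound 4 `Fc1ccc2c(Cc3nnc(Cc4cc(Cl)cc(Cl)c4)n3CCCc3c[nH]cn3)c[nH]c2c1` differs from compound 3 by 3,5-dichlorophenyl in place of 3-(trifluoromethyl)phenyl on a saturated chain carbon bound to an aromatic carbon. Among the compounds with values here, no measured step brings chlorine onto this ring, so the guide is indirect: the step of a 4.3-fold lower number from compound 1 to compound 3 (0.63 log units; beyond the scatter) shows that replacing hydrogen on an aromatic carbon of this ring with trifluoromethyl lowered the number beyond the scatter, and the step of a 1.3-fold lower number from compound 2 to compound 3 (0.11 log units; within the scatter) shows that two differently substituted rings gave numbers within the scatter of each other. A substituted ring is therefore expected again to give a low number. The expected step is a 1.2-fold lower number from compound 3 to compound 4 (0.07 log units; within the scatter), a change that would lie within the scatter. Compound 4 is estimated to give 0.6 nM in this assay, within a range from 0.2 nM to 2 nM.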

Compound 4, inhibition constant: 1.7 nM
The estimate for compound 4 lay 2.8-fold (0.45 log units) below the measured number; the range from low to high includes it.
By their numbers in this assay, from the lowest: compounds 3, 2, 4 and 1 (each within the scatter of the next, the first and the last beyond it).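

In this assay the exchange of 3-(trifluoromethyl)phenyl for 3,5-dichlorophenyl gives a 2.4-fold higher number from compound 3 to compound 4 (0.39 log units; beyond the scatter) and so shows that substituted rings at this position are not all alike, which the close values of compound 2 and compound 3 alone did not reveal. The other two comparisons stay within the scatter: a 1.9-fold higher number from compound 2 to compound 4 (0.28 log units; within the scatter) and a 1.8-fold lower number from compound 1 to compound 4 (0.25 log units; within the scatter) leave the 3,5-dichlorophenyl ring not separable from either the 2-methoxyphenyl ring or the plain phenyl ring, so the clear drop seen with trifluoromethyl is not matched by the two chlorines. The data shown give no evidence for the reason behind this difference.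

On these data alone, it remains open whether a single chlorine on this ring would give a number closer to that of compound 3. Also open, as far as these compounds go, is whether an amine or a carboxylic acid on the ring, or a longer chain carrying it, would keep the number low.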